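From methoxycarbonyl to ethoxycarbonyl on the shared core

A few compounds are considered here, and "the series" means these few. Any claim that something is new, unique, unknown or untested is made for them only; others in the source may bear on it.

In an ADME assay on MT4 cells (Homo sapiens) for cytotoxicity, read by MTT assay (a lower number here means that less compound is tolerated, a higher number that more compound is tolerated), compound 1 (`Cc1ccc(NC(=O)CSc2nncnc2-c2ccccc2Cl)c(Br)c1`) gives 45000 nM and compound 2 (`COC(=O)c1ccc(NC(=O)CSc2nncnc2-c2ccccc2Cl)c(Br)c1`) gives 59000 nM. For the measured compounds named here, these are the only two numbers so far, and they lie within the scatter of each other, so compound 2 holds no distinct place. Compound 3 (`CCOC(=O)c1ccc(NC(=O)CSc2nncnc2-c2ccccc2Cl)c(Br)c1`) is the next structure to be read in this assay. Its difference from compound 2 is methyl in place of hydrogen on a saturated chain carbon bound to an oxygen next to a carbonyl group, which also reads as methoxycarbonyl to ethoxycarbonyl. Going by the values given here, only one measured step bears on this change, a 1.3-fold higher number from compound 1 to compound 2 (0.12 log units; within the scatter), where methoxycarbonyl took the place of methyl on an aromatic carbon, and that step stayed within the scatter. Among the compounds with values here, no measured step yet includes ethoxycarbonyl, so no shift beyond the scatter is expected, in either direction. The estimated step is a 1.1-fold lower number from compound 2 to compound 3 (0.03 log units; within the scatter), which is expected to stay within the scatter. For compound 3 the estimate is 55000 nM, with an expected range of 30000 nM to 95000 nM.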

Compound 3, half-maximal cytotoxic concentration: 69000 nM
For compound 3 the middle estimate is 1.3-fold (0.10 log units) below the measured one; the range from low to high includes it.
By their numbers in this assay, from the lowest: compounds 1, 2 and 3 (each within the scatter of the next).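

For the compounds shown here, the step from methoxycarbonyl to ethoxycarbonyl is the first change made within the ester group itself. In this assay, methyl in place of hydrogen on a saturated chain carbon bound to an oxygen next to a carbonyl group stays within the scatter (a 1.2-fold higher number from compound 2 to compound 3 (0.07 log units; within the scatter)). Going by these compounds alone, the ethoxycarbonyl group also stays within the scatter when set against the methyl group on the aromatic carbon (a 1.5-fold higher number from compound 1 to compound 3 (0.19 log units; within the scatter)), so neither ester can be told from methyl at this position in this assay, and the three compounds form a single group with no distinct member. Nothing available accounts for why they read alike.

Still open, going by these compounds, is whether a longer chain on the ester oxygen, or a carboxylic acid or an amine on the aromatic carbon in place of the ester, would move the number beyond the scatter. The compounds shown also leave open whether this flat reading holds when the bromine, the chlorophenyl group or the thioacetamide link of the shared core is changed.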